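This account rests on a few compounds, and the source may have more. Where it says the series, first, only, none or still open, it means among the compounds named here.

Compound 1, `O=C1C=CCC/C1=C\C=C\c1ccccc1`, is a styryl-type enone that was tested in a functional assay on Bel7402/5-FU cells (Homo sapiens) for cytotoxicity, read by MTT assay, with a stated time of 72 h (a higher number here means a weaker inhibitor, a lower number a stronger inhibitor), where compound 1 gives 4200 nM. Among the measured compounds shown here, its one measured neighbour is compound 2, `O=C1C=CCC/C1=C\C=C\c1ccccc1[N+](=O)[O-]`, which carries a nitro in place of hydrogen on an aromatic carbon; in this assay compound 2 gives 5200 nM. For the measured compounds named here, the step of a 1.2-fold higher number from compound 1 to compound 2 (0.09 log units; within the scatter) shows that this change left the number where it was, so compound 1 stands at a value that lies within the scatter of the only other number on hand, and no compound can be called the stronger of the two.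

Compound 3, `CN(C)c1ccc(/C=C/C=C2\CCC=CC2=O)cc1`, differs from compound 1 in a single place: dimethylamino in place of hydrogen on an aromatic carbon. Going by the values given here, the only step that bears on it is the nitro substitution on the same ring, and that step, a 1.2-fold higher number from compound 1 to compound 2 (0.09 log units; within the scatter), was within the scatter. On that evidence the dimethylamino group is expected to behave likewise, with no step beyond the scatter, so the estimated step is a 1.1-fold lower number from compound 1 to compound 3 (0.02 log units; within the scatter). Compound 3 is therefore expected to give about 4000 nM in this assay, with a likely range from 1500 nM to 11000 nM.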

Compound 3, half-maximal inhibitory concentration: 1000 nM
Beside the measured number, compound 3's estimate is 4.0-fold (0.60 log units) above it; the whole stated range lies above it.
By their numbers in this assay, from the lowest: compound 3; then compounds 1 and 2 (each within the scatter of the next).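

In this assay, dimethylamino in place of hydrogen on an aromatic carbon, para to a large group, gives a 4.2-fold lower number from compound 1 to compound 3 (0.62 log units; beyond the scatter), a modest step but the first one here that lies beyond the scatter. The earlier nitro step, a 1.2-fold higher number from compound 1 to compound 2 (0.09 log units; within the scatter), had shown one substitution on this six-membered aromatic ring that left the number where it was, whereas this result shows that a substitution on the same ring can also lower the number, so the outcome there depends on the group that enters or on the ring carbon that carries it. Nothing on hand explains why this change lowers the number.

The compounds shown leave open whether the lowering needs both methyl groups of the dimethylamino, since neither a plain amino group nor a longer diethylamino group stands at this place, and whether a methoxy group there would give a similar step. They also leave open whether dimethylamino would give the same step on another carbon of the ring, and whether nitro would give a different one at the place para to the large group.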